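Methoxybenzyl ether regio-change: compound 3 to compound 4

The source may report more compounds than this note shows. Statements on the series, on what has been measured and on what is new or still open speak of the compounds shown alone.

Measured compounds:
compound 1 `COc1cccc(OC)c1OCCNCCOc1ccccc1OCc1cccc(C)c1` — 8.3
compound 2 `COc1cccc(OC)c1OCCNCCOc1ccccc1OCc1cccc([N+](=O)[O-])c1` — 8.85
compound 3 `COc1cccc(COc2ccccc2OCCNCCOc2c(OC)cccc2OC)c1` — 8.3

In a functional assay on Vas deferens for antagonist activity at Alpha-1A adrenergic receptor (Rattus norvegicus) (a higher number here means a more potent compound, by a factor of ten per unit of this negative logarithm, a lower number a less potent compound), compound 3 sits level with compound 1, the two together the lowest of the three numbers; the step of no change at the digits printed from compound 1 to compound 3 (within the scatter) lies within the scatter, whereas a number 0.55 log units lower from compound 2 to compound 3 (beyond the scatter) lies beyond it, as does a number 0.55 log units higher from compound 1 to compound 2 (beyond the scatter).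

Compound 4 `COc1ccc(COc2ccccc2OCCNCCOc2c(OC)cccc2OC)cc1` differs from compound 3 by 4-methoxyphenyl in place of 3-methoxyphenyl on a saturated chain carbon bound to an oxygen on an aromatic ring. For the measured compounds named here, both measured steps exchange one group for another at a fixed place on that ring; none of them moves a group to a new place, so no measured step bears directly on this change. With nothing pointing either way, compound 4 is expected to remain within the scatter of compound 3, a step of no change at the digits printed from compound 3 to compound 4 (within the scatter). Compound 4 is therefore estimated at 8.3, with a range from 7.7 to 8.9.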

Compound 4, negative logarithm of the antagonist equilibrium constant: 8.54
Beside the measured number, compound 4's estimate is 0.24 log units below it, within the range that was stated.
By their numbers in this assay, from the lowest: compounds 1, 3 and 4 (each within the scatter of the next); then compound 2.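

In this assay, for the compounds shown here, the 4-methoxyphenyl for 3-methoxyphenyl exchange (a number 0.24 log units higher from compound 3 to compound 4 (within the scatter)) is the first measured move of a group to a new place on this ring, and it stays within the scatter. The 4-methoxyphenyl compound also lies within the scatter of the 3-methylphenyl compound (a number 0.24 log units higher from compound 1 to compound 4 (within the scatter)), yet stays apart from the 3-nitrophenyl compound (a number 0.31 log units lower from compound 2 to compound 4 (beyond the scatter)), which leaves compound 2 separated from the other three. No measurement here offers an explanation for these steps.

As far as these compounds go, whether the same move behaves alike for 4-nitrophenyl or 4-methylphenyl remains open. So does the outcome with an amine or a carboxylic acid on this ring.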